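Swapping Azide for Hydroxyl on a Selenium Sugar Ring

This account rests on a few compounds, and the source may have more. Where it says the series, first, only, none or still open, it means among the compounds named here.

Two selenium-containing nucleoside analogues have been tested for their ability to kill colon cancer cells. In a functional assay on HCT-116 cells (Homo sapiens) for cytotoxicity, read by sulforhodamine B assay (on this read-out lower numbers stand for stronger inhibition and higher numbers for weaker inhibition), compound 1 `O=c1ccn(C2[Se][C@H](CO)[C@@H](O)[C@@H]2O)c(=O)[nH]1` gives > 100000 nM, which is a limit of the assay rather than a number. Going by the values given here, compound 2 `[N-]=[N+]=N[C@@H]1C(n2ccc(N)nc2=O)[Se][C@H](CO)[C@H]1O` is the only compound with a measured number, giving 78300 nM in this assay. Compound 3 `Nc1ccn(C2[Se][C@H](CO)[C@@H](O)[C@@H]2O)c(=O)n1` is not yet measured; it differs from compound 2 by hydroxy in place of azido on a saturated ring carbon. Among the compounds with values here, no measured step between two numbers exists here, only (the limit of > 100000 nM in this assay, at which 1 of the 2 values shown sits), so no change beyond the usual scatter is expected. Compound 3 is therefore estimated at 100000 nM, within 30000 nM to 300000 nM. That expectation means a step of a 1.3-fold higher number from compound 2 to compound 3 (0.11 log units; within the scatter).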

Compound 3, half-maximal inhibitory concentration: 7130 nM
Beside the measured number, compound 3's estimate is 14-fold (1.15 log units) above it; the measured number lies below the stated range.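

Going by these compounds alone, putting hydroxy in place of azido on this saturated ring carbon gives an 11-fold lower number from compound 2 to compound 3 (1.04 log units; beyond the scatter) in this assay, the first step here between two real numbers. It shows that cytotoxicity in these cells depends strongly on which group sits at this position, and that hydroxy goes with the stronger inhibition of the two. Nothing measured here explains the size of this step. The compounds shown leave open how an amine or a single fluorine atom on this carbon would compare. They also leave open whether hydroxy itself matters or only the loss of azido.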